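The compounds below may be only part of what the source reports. "The series", "measured", "known", "first", "only" and "open" are said of these compounds alone.

For the measured compounds named here, compound 1 `C[C@H](NC(=O)C(=O)NCc1ccc(Cl)cc1)C(=O)N[C@@H](CC(=O)O)C(=O)COc1c(F)c(F)cc(F)c1F` gives 8.4 nM in a functional assay on Jurkat cells (Homo sapiens) (a higher number here means a weaker inhibitor, a lower number a stronger inhibitor), the lowest of the three numbers measured so far. Compound 2 `C[C@H](NC(=O)C(=O)NCCC1CCCC1)C(=O)N[C@@H](CC(=O)O)C(=O)COc1c(F)c(F)cc(F)c1F` sits nearest, at 11 nM, and compound 3 `Cc1ccccc1CNC(=O)C(=O)N[C@@H](C)C(=O)N[C@@H](CC(=O)O)C(=O)COc1c(F)c(F)cc(F)c1F` furthest, at 52 nM. The account follows the step to compound 4 `C[C@H](NC(=O)C(=O)NCc1ccccc1F)C(=O)N[C@@H](CC(=O)O)C(=O)COc1c(F)c(F)cc(F)c1F`, which differs from compound 1 by one change: 2-fluorophenyl in place of 4-chlorophenyl on a saturated chain carbon bound to an amide-type nitrogen. Two measured steps start from compound 1 and replace the same 4-chlorophenyl. One, a 1.3-fold higher number from compound 1 to compound 2 (0.12 log units; within the scatter), stays within the scatter; the other, a 6.2-fold higher number from compound 1 to compound 3 (0.79 log units; beyond the scatter), costs a modest amount, and a 4.7-fold higher number from compound 2 to compound 3 (0.67 log units; beyond the scatter) echoes it. Of these, the step to compound 3 is the closer comparison, since it too exchanges 4-chlorophenyl for another substituted phenyl on that carbon, whereas compound 2 carries cyclopentylmethyl there. Compound 4 is therefore expected to give a somewhat higher number than compound 1, short of the loss seen with compound 3, because of a 6.2-fold higher number from compound 1 to compound 3 (0.79 log units; beyond the scatter). The estimate for compound 4 is 18 nM, within 8 nM to 45 nM, meaning an expected step of a 2.1-fold higher number from compound 1 to compound 4 (0.33 log units; beyond the scatter).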

Compound 4, half-maximal inhibitory concentration: 207 nM
Compound 4: middle estimate off by 12-fold (1.06 log units), on the low side; measured number outside the range, above it.
By their numbers in this assay, from the lowest: compounds 1 and 2 (each within the scatter of the next); then compound 3; then compound 4.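

The exchange of 4-chlorophenyl for 2-fluorophenyl on this carbon proves far from neutral (a 25-fold higher number from compound 1 to compound 4 (1.39 log units; beyond the scatter)), although the two groups match in every count computed here, including seven heavy atoms and one aromatic ring each. Those counts therefore do not account for the numbers at this position, and the step to compound 4 is also large when measured from the cyclopentylmethyl group (a 19-fold higher number from compound 2 to compound 4 (1.27 log units; beyond the scatter)). Among the two phenyls bearing a group at the 2-position, fluoro in place of methyl raises the number further (a 4.0-fold higher number from compound 3 to compound 4 (0.60 log units; beyond the scatter)), and no measurement available here explains this order.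

Compound 4 changes both the halogen and its ring position relative to compound 1, so the two contributions remain unseparated. A 2-chlorophenyl or 4-fluorophenyl group on this carbon would separate them.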